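A methyl group on the phenyl ring of compound 3

The source may report more compounds than this note shows. Statements on the series, on what has been measured and on what is new or still open speak of the compounds shown alone.

compound 1 `N#Cc1c(-c2ccc(F)cc2)nc2c(/N=N/c3ccc(S(N)(=O)=O)cc3)c(N)nn2c1N`: 2960 nM
compound 2 `N#Cc1c(-c2ccc(Cl)cc2)nc2c(/N=N/c3ccc(S(N)(=O)=O)cc3)c(N)nn2c1N`: 2070 nM
compound 3 `N#Cc1c(-c2ccccc2)nc2c(/N=N/c3ccc(S(N)(=O)=O)cc3)c(N)nn2c1N`: 660 nM

In a functional assay on MCF7 cells (Homo sapiens) for antiproliferative activity, read by MTT assay, with a stated time of 48 h (a lower number here means a stronger inhibitor, a higher number a weaker inhibitor), compound 3 stands at 660 nM as the lowest of the three numbers. Compound 4 `Cc1ccc(-c2nc3c(/N=N/c4ccc(S(N)(=O)=O)cc4)c(N)nn3c(N)c2C#N)cc1` has not yet been measured. It carries methyl in place of hydrogen on an aromatic carbon, para to a large group, so that phenyl becomes 4-methylphenyl (methyl in place of hydrogen on an aromatic carbon). The nearest evidence is the pair of halogen steps, a 4.5-fold lower number from compound 1 to compound 3 (0.65 log units; beyond the scatter) and a 3.1-fold lower number from compound 2 to compound 3 (0.50 log units; beyond the scatter) on the loss of fluoro and chloro from that carbon. The two halogen compounds themselves are separated by only a 1.4-fold lower number from compound 1 to compound 2 (0.16 log units; within the scatter) in this comparison. Within the data shown here, both compounds with a halogen there therefore sit higher than compound 3, but no compound with methyl there has been measured, so this guide is loose. A modest rise is expected, no larger than the halogen steps. The expected step is a 2.0-fold higher number from compound 3 to compound 4 (0.29 log units; within the scatter) in this assay on this reading. Compound 4 is estimated at 1300 nM with an expected range from 600 nM to 2900 nM for repeated measurements.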

Compound 4, half-maximal inhibitory concentration: 6800 nM
Compound 4: the middle estimate sits 5.2-fold (0.72 log units) below what was measured; the whole stated range lies below it.
By their numbers in this assay, from the lowest: compound 3; then compounds 2 and 1 (each within the scatter of the next); then compound 4.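

In this assay this carbon of the phenyl ring proves able to carry a large step, not only the modest ones the halogens gave: methyl in place of hydrogen gives the large rise (a 10-fold higher number from compound 3 to compound 4 (1.01 log units; beyond the scatter)). Methyl also stands apart from both halogens at the same carbon (a 3.3-fold higher number from compound 2 to compound 4 (0.52 log units; beyond the scatter); a 2.3-fold higher number from compound 1 to compound 4 (0.36 log units; beyond the scatter)), which makes compound 4 the weakest of the four compounds. All three groups shown at this carbon therefore give higher numbers than hydrogen, and no measurement here accounts for the order among them.

The compounds shown leave open whether a longer chain such as ethyl at this carbon would rise further still. They also leave open whether an amine, a hydroxyl or a carboxylic acid there would give a number nearer to that of compound 3.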